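Trimming one fluorine from the difluorophenyl group

A few compounds are considered here, and "the series" means these few. Any claim that something is new, unique, unknown or untested is made for them only; others in the source may bear on it.

Three measured compounds share one core and differ only in the group attached to one of its aromatic carbons. Compound 1 `CC#CC(CC(=O)O)c1ccc(OCc2ccn3cc(-c4ccccc4)nc3c2)cc1` carries a plain phenyl group, and in an assay on isolated protein for agonist activity at Free fatty acid receptor 1 (Homo sapiens) (a lower number here means that less compound is needed, a higher number that more compound is needed for the effect), compound 1 gives 1260 nM. Compound 2 `CC#CC(CC(=O)O)c1ccc(OCc2ccn3cc(-c4ccc(C5CCCCC5)cc4)nc3c2)cc1` carries a 4-cyclohexylphenyl group, and in this assay compound 2 gives 559 nM; this is the step of a 2.3-fold lower number from compound 1 to compound 2 (0.35 log units; beyond the scatter). Compound 3 `CC#CC(CC(=O)O)c1ccc(OCc2ccn3cc(-c4cc(F)ccc4F)nc3c2)cc1` carries a 2,5-difluorophenyl group, and in this assay compound 3 gives 639 nM, the second highest of the three numbers. The steps of a 2.0-fold lower number from compound 1 to compound 3 (0.29 log units; within the scatter) and a 1.1-fold higher number from compound 2 to compound 3 (0.06 log units; within the scatter) both lie within the scatter, so compound 3 is not separated from either neighbour.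

Compound 4 `CC#CC(CC(=O)O)c1ccc(OCc2ccn3cc(-c4ccccc4F)nc3c2)cc1` differs from compound 3 in one place: hydrogen in place of fluoro on an aromatic carbon. For the measured compounds named here, the only measured step that bears on this is the one that put both fluorines in, a 2.0-fold lower number from compound 1 to compound 3 (0.29 log units; within the scatter), which itself stayed within the scatter. Taking one fluorine out again is expected to undo at most part of that, so the step of a 1.3-fold higher number from compound 3 to compound 4 (0.12 log units; within the scatter) is expected to stay within the scatter. Compound 4 is therefore estimated at 850 nM, with a range from 400 nM to 1800 nM.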

Compound 4, half-maximal effective concentration: 705 nM
Beside the measured number, compound 4's estimate is 1.2-fold (0.08 log units) above it, and the stated range covers the measured number.
By their numbers in this assay, from the lowest: compounds 2, 3, 4 and 1 (each within the scatter of the next, the first and the last beyond it).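

Taking out the fluoro on the aromatic carbon para to the other fluoro group, which turns 2,5-difluorophenyl into 2-fluorophenyl, gives a small step in this assay (a 1.1-fold higher number from compound 3 to compound 4 (0.04 log units; within the scatter)), so hydrogen and fluoro cannot be told apart on this carbon. Going from no fluoro to one is also a step within the scatter (a 1.8-fold lower number from compound 1 to compound 4 (0.25 log units; within the scatter)), as is the exchange of 4-cyclohexylphenyl for 2-fluorophenyl (a 1.3-fold higher number from compound 2 to compound 4 (0.10 log units; within the scatter)), so compound 4 is separated from none of the other three compounds. Nothing available here explains why these numbers lie so close together. 

As far as these compounds go, whether a chloro, methoxy or amino group on this same carbon would give a step beyond the scatter stays open. Also open, from the compounds shown here alone, is whether a single fluoro on another carbon of the phenyl ring would behave in the same way.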